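Cytotoxicity notes on a urea-to-amide change

This account rests on a few compounds, and the source may have more. Where it says the series, first, only, none or still open, it means among the compounds named here.

Compound 1 `CCN(CC)c1cc2[nH]c(C3CCCCC3)nc2cc1NC(=O)NCc1ccccc1` has been read in an ADME assay on Vero cells (Chlorocebus sabaeus) for cytotoxicity, read by resazurin assay, with a stated time of 3 days; a lower number here means a stronger inhibitor, a higher number a weaker inhibitor. In that assay compound 1 gives > 100 ug/mL, which is a limit of the assay rather than a number. Compound 2 `O=C(NCc1ccccc1)Nc1cc2nc(C3CCCCC3)[nH]c2cc1N1CCCC1` carries pyrrolidin-1-yl in place of diethylamino on an aromatic carbon. In this assay compound 2 gives > 100 ug/mL, again a limit. The step reads a step that the two limits leave unreadable from compound 1 to compound 2. Compound 3 `CCCN(CCC)c1cc2[nH]c(C3CCCCC3)nc2cc1NC(=O)OCc1ccccc1` gives > 100 ug/mL in this assay, also a limit. All three values sit at the limit of > 100 ug/mL in this assay, at which 3 of the 3 values shown sit, so compound 1 stands where every measured compound stands, with no number to set it against.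

Compound 4 `CCN(CC)c1cc2[nH]c(C3CCCCC3)nc2cc1NC(=O)c1cnccn1` is not yet measured. It differs from compound 1 as follows: pyrazin-2-yl in place of benzylamino on a carbonyl carbon. Among the measured compounds shown here, no measured step touches the carbonyl carbon, and the single measured step is unreadable. For the measured compounds named here, nothing among the measured values points away from the limit, so compound 4 is expected to stay there, with an expected step of a number no higher from compound 1 to compound 4 (the limit leaves the size open). The estimate for compound 4 in this assay is 100 ug/mL, between 40 ug/mL and 200 ug/mL.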

Compound 4, half-maximal inhibitory concentration: > 100 ug/mL
Compound 4: a limit, no number; the forecaster's own chance of this, stated with the estimate: 80%; the middle value lies on the limit itself.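

Among the compounds shown here, compound 1 and compound 4 both stand at a limit, so no step between them can be read, and the change on the carbonyl carbon gives no size in this assay. The compounds shown leave open what number, if any, lies behind each limit for compound 1, compound 2, compound 3 and compound 4.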